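The source may report more compounds than this note shows. Statements on the series, on what has been measured and on what is new or still open speak of the compounds shown alone.

In an ADME assay on L6 cells (Rattus norvegicus) for inhibition, read by resazurin assay, with a stated time of 72 h (a higher number here means a weaker inhibitor, a lower number a stronger inhibitor), three compounds have been measured:

Compound 1 `CSC[C@H]1O[C@@H](n2cnc3c(N)nc(Cl)nc32)[C@H](OC(C)=O)[C@@H]1OC(C)=O`: 216000 nM
Compound 2 `CC(=O)O[C@@H]1[C@H](OC(C)=O)[C@@H](CN=[N+]=[N-])O[C@H]1n1cnc2c(N)nc(Cl)nc21`: 141000 nM
Compound 3 `CC(=O)NC[C@H]1O[C@@H](n2cnc3c(N)nc(Cl)nc32)[C@H](OC(C)=O)[C@@H]1OC(C)=O`: 190000 nM

The three numbers form one tight group, and compound 3 stands inside it. The steps that reach it are a 1.1-fold lower number from compound 1 to compound 3 (0.06 log units; within the scatter) and a 1.3-fold higher number from compound 2 to compound 3 (0.13 log units; within the scatter). The remaining step at the same place, a 1.5-fold lower number from compound 1 to compound 2 (0.19 log units; within the scatter), also stays within the scatter. Across methylsulfanyl, azido and acetamido, then, this assay has so far shown no step beyond the scatter.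

Compound 4 `CC(=O)O[C@@H]1[C@H](OC(C)=O)[C@@H](CN2C(=O)c3ccccc3C2=O)O[C@H]1n1cnc2c(N)nc(Cl)nc21` changes that same place once more: a group of 11 heavy atoms (8 carbon, 1 nitrogen, 2 oxygen; one five-membered non-aromatic ring with 1 hetero atom, one six-membered aromatic ring of carbon only) in place of a group of 4 heavy atoms (2 carbon, 1 nitrogen, 1 oxygen; no ring), on a saturated chain carbon bound to a saturated ring carbon. This change goes further than the earlier ones, since none of the three measured groups contains a ring, and the data therefore do not show how a group of this kind behaves. Going by the values given here, the three small steps are the only guide, so no step beyond the scatter is expected, and no direction can be favoured with any confidence. The expected step is a 1.1-fold lower number from compound 3 to compound 4 (0.05 log units; within the scatter). The range is kept wide to allow for the much larger entering group. For compound 4 the estimated value is 170000 nM, with an expected range of 70000 nM to 320000 nM.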

Compound 4, half-maximal inhibitory concentration: 144000 nM
Estimate against measurement, compound 4: 1.2-fold (0.07 log units) above; measured number inside the range.
By their numbers in this assay, from the lowest: compounds 2, 4, 3 and 1 (each within the scatter of the next).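

At the saturated chain carbon bound to a saturated ring carbon, this assay now gives a reading for a group with a five-membered non-aromatic ring and a six-membered aromatic ring of carbon only, and this group leaves the number inside the same tight cluster: there is a 1.3-fold lower number from compound 3 to compound 4 (0.12 log units; within the scatter) and a 1.0-fold higher number from compound 2 to compound 4 (0.01 log units; within the scatter) and also a 1.5-fold lower number from compound 1 to compound 4 (0.18 log units; within the scatter) at this place. The earlier compounds had shown this flatness only for methylsulfanyl, azido and acetamido, none of which contains a ring, so the result extends it to a group of 11 heavy atoms with 0 hydrogen-bond donors, and still no step among the four compounds lies beyond the scatter. Nothing available accounts for this lack of response.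

The compounds shown leave open whether this place would stay as flat with an amine, a carboxylic acid or a longer chain in the same position. All four also share the rest of the core, so they cannot tell whether a change elsewhere on it would move the number beyond the scatter.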